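Ring-nitrogen substituent: benzyl to ethyl, compound 4

A few compounds are considered here, and "the series" means these few. Any claim that something is new, unique, unknown or untested is made for them only; others in the source may bear on it.

Measured in a functional assay on L1210 cells (Mus musculus) for cytotoxicity, read by cell counting, with a stated time of 2 days; on this read-out higher numbers stand for weaker inhibition and lower numbers for stronger inhibition:
- compound 1 `CC(C)(C)c1ccc(CN2C(=O)S/C(=C\c3cccc(N)c3)C2=O)cc1` gives 223000 nM
- compound 2 `Nc1ccc(/C=C2\SC(=O)N(Cc3ccccc3)C2=O)cc1` gives 38000 nM
- compound 3 `C=C(Br)C(=O)Nc1ccc(/C=C2\SC(=O)N(Cc3ccccc3)C2=O)cc1` gives 1100 nM

Compound 2 stands second highest of the three numbers in this assay: compound 1 sits above it, beyond the scatter, while compound 3 sits far below it, the step being a 35-fold lower number from compound 2 to compound 3 (1.54 log units; beyond the scatter). That step alters the aromatic amine and leaves the substituent on the ring nitrogen untouched, so it says nothing directly about the change considered here.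

Compound 4 `CCN1C(=O)S/C(=C\c2ccc(N)cc2)C1=O` differs from compound 2 only at the ring nitrogen: methyl in place of phenyl on a saturated chain carbon bound to an amide-type nitrogen in a ring. The pair compound 1 versus compound 2 also differs in two places at once, so it cannot be read as a clean step on the benzyl group. Going by the values given here, no measured step therefore bears on the benzyl-to-ethyl change, and the direction of any effect is unknown from these three compounds.

In the absence of a relevant step, compound 4 is estimated to land near compound 2, with the expected step being a 1.6-fold higher number from compound 2 to compound 4 (0.20 log units; within the scatter), and a wide range to allow for either direction. Compound 4 is expected at 60000 nM, between 15000 nM and 250000 nM in this assay.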

Compound 4, half-maximal inhibitory concentration: 82000 nM
Estimate against measurement, compound 4: 1.4-fold (0.14 log units) below, and the stated range covers the measured number.
By their numbers in this assay, from the lowest: compound 3; then compound 2; then compound 4; then compound 1.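

In this assay, the substituent on the ring nitrogen now has its first reading from a change in one place: a 2.2-fold higher number from compound 2 to compound 4 (0.33 log units; beyond the scatter). With methyl in place of phenyl on the saturated chain carbon, the aromatic ring is not essential for a measurable value, as compound 4 still gives 82000 nM, although the step is modest and goes towards weaker inhibition. Set against a 35-fold lower number from compound 2 to compound 3 (1.54 log units; beyond the scatter), this change is the smaller of the two steps from compound 2, and no measurement at hand accounts for either step.

Because benzyl to ethyl removes an aromatic ring and shortens the substituent in one move, the two contributions remain unseparated, and a longer chain such as butyl, a cyclohexylmethyl group or a benzyl group carrying a carboxylic acid would be needed to tell them apart. From the compounds shown here alone, it also remains open whether the large gain seen with the (1-bromoethenyl)carbonyl group on the aromatic amine carries over when ethyl rather than benzyl sits on the ring nitrogen.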